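Phenyl for benzyloxy on the carbonyl of compound 3

A few compounds are considered here, and "the series" means these few. Any claim that something is new, unique, unknown or untested is made for them only; others in the source may bear on it.

In a functional assay on SEM cells (Homo sapiens) for cytotoxicity, with a stated time of 72 h (a higher number here means that more compound is needed for the effect, a lower number that less compound is needed), compound 1 (`C=C[C@@](C)(/C=C/c1ccc(OS(=O)(=O)C(F)(F)F)cc1)CCC=C(C)C`) gives > 36600 nM, which is a limit. Compound 2 (`C=C[C@@](C)(/C=C/c1ccc(O)cc1)CC/C=C/C(=O)OCC`) gives > 36600 nM, also a limit. Compound 3 (`C=C[C@@](C)(/C=C/c1ccc(O)cc1)CC/C=C/C(=O)OCc1ccccc1`) gives > 36600 nM, again a limit. Going by the values given here, the series therefore offers no number so far: the limit of > 36600 nM in this assay, at which 3 of the 3 values shown sit. Among the compounds with values here, the one measured step that bears on the next change is a step that the two limits leave unreadable from compound 2 to compound 3, and it offers no size to carry over. Compound 4 (`C=C[C@@](C)(/C=C/c1ccc(O)cc1)CC/C=C/C(=O)c1ccccc1`) is reached by phenyl in place of benzyloxy on a carbonyl carbon, with phenyl in place of benzyloxy on a carbonyl carbon. No step beyond the scatter is expected in this assay, and no direction can be assigned. The expected change is an at least 1.2-fold lower number from compound 3 to compound 4 (0.08 log units; that floor lies within the scatter). The estimate for compound 4 is 30000 nM, with an expected range of 12000 nM to 60000 nM.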

Compound 4, half-maximal effective concentration: > 36600 nM
Compound 4 gave a limit, no number; the forecaster's own chance of this, stated with the estimate: 60%; at least 1.2-fold (0.08 log units) between middle value and limit.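

The steps among compound 2, compound 3 and compound 4 cannot be read, as all three rest on one limit: the limit of > 36600 nM in this assay, at which 4 of the 4 values shown sit.

The compounds shown leave open whether any group on the carbonyl carbon gives a number rather than a limit.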